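This account rests on a few compounds, and the source may have more. Where it says the series, first, only, none or still open, it means among the compounds named here.

Of the compounds shown here, three built on one shared core have been tested in an ADME assay on MRC5 cells (Homo sapiens) for inhibition, with a stated time of 72 h; on this read-out higher numbers stand for an effect only at larger amounts of compound and lower numbers for an effect already at smaller amounts. Compound 1 `COc1cccc(OC)c1C(=O)Nc1c[nH]nc1C(=O)Nc1ccncc1` returns only a limit of the assay rather than a number, > 50000 nM. Compound 2 `COc1cccc(OC)c1C(=O)Nc1c[nH]nc1C(=O)NC1CCCCCC1` gives 42000 nM. Compound 3 `COc1cccc(OC)c1C(=O)Nc1c[nH]nc1C(=O)NCCCOC(C)C` again stops at a limit, > 50000 nM. Compound 3 thus stands at the edge of what the assay can report, sharing that position with one other compound (the limit of > 50000 nM in this assay, at which 2 of the 3 values shown sit). The measured steps, an at least 1.1-fold lower number from compound 1 to compound 2 (0.07 log units; that floor lies within the scatter), an at least 1.1-fold higher number from compound 2 to compound 3 (0.07 log units; that floor lies within the scatter) and a step that the two limits leave unreadable from compound 1 to compound 3, all swap the group on the amide-type nitrogen, and none of them shows a change that the scatter would not also produce. Compound 4 `COC(=O)c1n[nH]cc1NC(=O)c1c(OC)cccc1OC` has not yet been measured; here the change sits at the carbonyl carbon instead: methoxy in place of (3-isopropoxypropyl)amino on a carbonyl carbon. Given that compound 3 sits at the limit > 50000 nM while an at least 1.1-fold higher number from compound 2 to compound 3 (0.07 log units; that floor lies within the scatter) remained within the scatter, the expected step to compound 4 is a number no higher from compound 3 to compound 4 (the limit leaves the size open). Compound 4 is estimated at 50000 nM, between 20000 nM and 120000 nM, most likely reported once more as a limit.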

Compound 4, half-maximal effective concentration: > 50000 nM
Compound 4 gave a limit, no number; the forecaster's own chance of this, stated with the estimate: 70%; the middle value sits exactly at the limit.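

Until now every change sat on the amide-type nitrogen; compound 4 shows that replacing the whole (3-isopropoxypropyl)amino group with a much smaller methoxy on the carbonyl carbon still yields no readable change in this assay. Among these compounds, the one step that can be read is an at least 1.1-fold higher number from compound 2 to compound 4 (0.07 log units; that floor lies within the scatter), while the steps linking compound 4 to compound 1 and compound 3 cannot be read. The series now gathers at a single ceiling, which leaves little room to rank these groups: the limit of > 50000 nM in this assay, at which 3 of the 4 values shown sit.

From the compounds shown here alone, it remains open whether another group on this carbonyl carbon, such as a carboxylic acid or an amide carrying a dimethylaminoethyl chain, would give a clear number in this assay. Going by these compounds, how far compound 1, compound 3 and compound 4 differ from one another also stays unknown.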